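Dichlorophenyl rearrangement in a dienone series

A few compounds are considered here, and "the series" means these few. Any claim that something is new, unique, unknown or untested is made for them only; others in the source may bear on it.

compound 1 `O=C(/C=C/c1ccc(Oc2ncnc3ccc(Cl)cc23)cc1)/C=C/c1c(Cl)cccc1Cl` — 9300 nM
compound 2 `O=C(/C=C/c1ccc(Cl)c(Cl)c1)/C=C/c1ccccc1Oc1ncnc2ccc(Cl)cc12` — 18300 nM

In a functional assay on PC-3 cells (Homo sapiens) for inhibition, read by MTT assay, with a stated time of 72 h (on this read-out higher numbers stand for weaker inhibition and lower numbers for stronger inhibition), compound 1 gives 9300 nM and compound 2 gives 18300 nM. The two numbers lie within the scatter of each other, so compound 1 cannot be set apart from compound 2 on these data. Compound 3 `O=C(/C=C/c1ccc(Oc2ncnc3ccc(Cl)cc23)cc1)/C=C/c1cccc(Cl)c1Cl` is not yet measured. It differs from compound 1 by 2,3-dichlorophenyl in place of 2,6-dichlorophenyl on a double-bonded chain carbon bound to a double-bonded chain carbon. Among the measured compounds shown here, no step between measured compounds is available, so the expectation rests on compound 1 alone. In this assay the expected step of a 1.0-fold higher number from compound 1 to compound 3 (0.01 log units; within the scatter) is none beyond the scatter. Compound 3 is estimated at 9500 nM, ranging from 3500 nM to 26000 nM.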

Compound 3, half-maximal inhibitory concentration: 10200 nM
For compound 3 the middle estimate is 1.1-fold (0.03 log units) below the measured one; low and high end bracket the measured number.
By their numbers in this assay, from the lowest: compounds 1, 3 and 2 (each within the scatter of the next).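

In this assay, 2,3-dichlorophenyl in place of 2,6-dichlorophenyl on a double-bonded chain carbon bound to a double-bonded chain carbon gives the first step read at this position (a 1.1-fold higher number from compound 1 to compound 3 (0.04 log units; within the scatter)), and compound 1 and compound 3 cannot be told apart. For this pair, the arrangement of the two chlorines on the phenyl therefore leaves no mark beyond the scatter. Nothing measured here speaks to the reason for this result.

Open, on these data alone, is whether an unsubstituted phenyl, or a phenyl carrying methoxy or an amine instead of chlorine, would give a step beyond the scatter at this position.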